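The source may report more compounds than this note shows. Statements on the series, on what has been measured and on what is new or still open speak of the compounds shown alone.

Compounds measured so far: compound 1 `Cc1ccc2c(c1)C(=O)/C(=C/c1ccc(Br)cc1)CN2CC(=O)O` with 28.2% in an assay on HL-60 cells for inhibition of glutathione S-transferase P (Homo sapiens), read by spectrophotometry, tested at 20 uM (a higher number here means more inhibition at the concentration tested (going by the name of the read-out), a lower number less inhibition), and compound 2 `Cc1ccc2c(c1)C(=O)/C(=C/c1ccc(F)cc1)CN2CC(=O)O` with 16.1% in this assay.

Compound 2 stands lowest of the two, below compound 1 by a number 12.1 percentage points lower from compound 1 to compound 2 (beyond the scatter). Compound 3 `COc1ccc(/C=C2\CN(CC(=O)O)c3ccc(C)cc3C2=O)cc1` differs from compound 2 by methoxy in place of fluoro on an aromatic carbon. Among the compounds with values here, no measured step covers methoxy in place of fluoro; the one step known, from bromo to fluoro, is modest and offers little guidance here. A step within the scatter is therefore expected for compound 3, giving a number 3.9 percentage points higher from compound 2 to compound 3 (within the scatter). Compound 3 is estimated at 20%, between 8% and 34%.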

Compound 3, a percentage reported as inhibition, at one concentration (the size of the read-out at that concentration, not a potency): 17.5%
Beside the measured number, compound 3's estimate is 2.5 percentage points above it, and the stated range covers the measured number.
By their numbers in this assay, from the lowest: compounds 2 and 3 (each within the scatter of the next); then compound 1.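

In this assay, methoxy in place of fluoro on the aromatic carbon para to a large group gives a number 1.4 percentage points higher from compound 2 to compound 3 (within the scatter), so the two groups cannot be told apart here, although methoxy carries a hydrogen-bond acceptor and fluoro does not. Bromo stays apart from methoxy too, with a number 10.7 percentage points lower from compound 1 to compound 3 (beyond the scatter), leaving compound 1 with the highest number of the three. Nothing available explains why bromo stands apart from the other two groups.

Still open, as far as these compounds go, is how chloro, an amine or a longer chain such as ethoxy would read at this position. Also open, from the compounds shown here alone, is whether any group there could exceed compound 1.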